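Fluoro for Bromo in a Series Without Measurable Potency

A few compounds are considered here, and "the series" means these few. Any claim that something is new, unique, unknown or untested is made for them only; others in the source may bear on it.

Three compounds sharing one core were tested in a functional assay on A549 cells (Homo sapiens) for cytotoxicity, read by MTT assay, with a stated time of 48 h (on this read-out higher numbers stand for weaker inhibition and lower numbers for stronger inhibition), and none of them gave a number. Compound 1 `O=c1ccoc2cc(OCc3cn(Cc4ccccc4Br)nn3)ccc12` returns only the limit of the assay, > 100000 nM. Compound 2 `CC(C)(C)c1ccc(Cn2cc(COc3ccc4c(=O)ccoc4c3)nn2)cc1` likewise returns only the limit > 100000 nM. Compound 3 `C#CCOc1ccc2c(=O)ccoc2c1` also returns only the limit > 100000 nM. All three values thus sit at the limit of > 100000 nM in this assay, at which 3 of the 3 values shown sit, so compound 1 stands level with the others and nothing ranks them. Compound 4 `O=c1ccoc2cc(OCc3cn(Cc4ccccc4F)nn3)ccc12` differs from compound 1 by fluoro in place of bromo on an aromatic carbon. Within the data shown here, no measured step for such a change exists in this assay. The step that the limit leaves unreadable from compound 1 to compound 4 is expected to be none beyond the scatter. Compound 4 is expected to give about 150000 nM, within 50000 nM to 500000 nM, most likely again as a limit.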

Compound 4, half-maximal inhibitory concentration: 10800 nM
Compound 4: the middle estimate sits 14-fold (1.14 log units) above what was measured, outside the stated range (below it).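

In this assay, from the compounds shown here alone, the halogen on the benzyl group proves to matter: going from 2-bromobenzyl to 2-fluorobenzyl gives an at least 9.2-fold lower number from compound 1 to compound 4 (0.96 log units; beyond the scatter), a step whose full size stays unknown, as one end of it is a limit. The core thus can give a measurable value with the right group at this place. Compound 4 alone yields a number rather than a limit: the limit of > 100000 nM in this assay, at which 3 of the 4 values shown sit.

The compounds shown leave open whether the gain is specific to fluoro, or whether chloro, methyl or plain hydrogen at this place would do the same. They also leave open how fluoro would behave elsewhere on the six-membered ring.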